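Series notes: methoxy for methyl on the sulfonamide aryl ring

The compounds below may be only part of what the source reports. "The series", "measured", "known", "first", "only" and "open" are said of these compounds alone.

The compounds share a sulfonamide-linked core carrying a substituted phenyl ring. Compound 1 `Cc1cccc(S(=O)(=O)Nc2ccc(-c3nc4ccccc4o3)cc2)c1` has a 3-methylphenyl group on the sulfonyl side. In an ADME assay on HEK293 cells (Homo sapiens) for cytotoxicity, read by resazurin assay, with a stated time of 48 h (on this read-out lower numbers stand for higher toxicity in this test and higher numbers for lower toxicity in this test), compound 1 reaches only the limit of the assay, > 100000 nM, so no number is known for it; it sits at the limit of > 100000 nM in this assay, at which 1 of the 3 values shown sits. Compound 2 `C=Cc1ccc(S(=O)(=O)Nc2ccc3oc(-c4ccccc4)nc3c2)cc1` and compound 3 `Cc1ccc(S(=O)(=O)Nc2ccc3oc(-c4ccccc4)nc3c2)cc1` carry the sulfonamide on the other side of the core. In this assay, going by the values given here, compound 2 gives 53000 nM and compound 3 gives 75000 nM; the step of a 1.4-fold higher number from compound 2 to compound 3 (0.15 log units; within the scatter) is the only measured step and concerns a vinyl-to-methyl change, not the one considered here.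

Compound 4 `COc1cccc(S(=O)(=O)Nc2ccc(-c3nc4ccccc4o3)cc2)c1` is compound 1 with methoxy in place of methyl on an aromatic carbon. Among the compounds with values here, no measured step speaks to this change, and the single measured step, which lies within the scatter, is of a different kind. No move beyond the scatter is therefore expected. Compound 4 is expected to stay at the limit, estimated at 100000 nM, with a range of 50000 nM to 200000 nM. The expected step is a number no higher from compound 1 to compound 4 (the limit leaves the size open).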

Compound 4, half-maximal cytotoxic concentration: > 100000 nM
Compound 4 was reported as a limit; the forecaster's own chance of this, stated with the estimate: 70%; the middle value lies on the limit itself.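

Going by these compounds alone, compound 1 and compound 4 are each reported only as a limit, so no step between them can be read for methoxy in place of methyl: the limit of > 100000 nM in this assay, at which 2 of the 4 values shown sit. The compounds shown leave open how far the change from 3-methylphenyl to 3-methoxyphenyl shifts the half-maximal cytotoxic concentration, and in which direction it does so.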